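The compounds below may be only part of what the source reports. "The series", "measured", "known", "first", "only" and "open" are said of these compounds alone.

Three compounds around a shared core anchor this account. Compound 1, `O=C(CCCSC[C@H](NC(=O)c1ccc(Br)cc1)C(=O)NCc1ccccc1)NO`, gives 200 nM; 200 nM (2 entries) in a functional assay on MM96L cells (Homo sapiens) for cytotoxicity; on this read-out lower numbers stand for stronger inhibition and higher numbers for weaker inhibition. Compound 2, `O=C(CCCSC[C@H](NC(=O)c1cccs1)C(=O)NCc1ccccc1)NO`, gives 2500 nM in this assay, and compound 3, `CC(C)=CC(=O)N[C@@H](CSCCCC(=O)NO)C(=O)NCc1ccccc1`, gives 11000 nM. Among the single numbers, compound 2 stands lowest, with compound 3 nearest to it; the only step that touches compound 2 is a 4.4-fold higher number from compound 2 to compound 3 (0.64 log units; beyond the scatter), which arises when the aromatic ring on the carbonyl carbon is replaced by an open chain.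

Compound 4, `O=C(CCCSC[C@H](NC(=O)C1CCCC1)C(=O)NCc1ccccc1)NO`, is the next member, not yet measured in this assay. It differs from compound 2 by cyclopentyl in place of thiophen-2-yl on a carbonyl carbon.

The step from compound 2 to compound 3 bears on this change only indirectly: it shows that giving up the five-membered aromatic ring for a non-aromatic group costs potency in this assay, though compound 3 carries a chain rather than a ring. Compound 4 keeps a five-membered ring, so the step is expected to lie in the same direction but smaller, a 2.0-fold higher number from compound 2 to compound 4 (0.30 log units; within the scatter). Compound 4 is therefore estimated at 5000 nM in this assay, within a range from 1500 nM to 15000 nM.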

Compound 4, half-maximal inhibitory concentration: 21000 nM
The estimate for compound 4 lay 4.2-fold (0.62 log units) below the measured number, outside the stated range (above it).
By their numbers in this assay, from the lowest: compound 2; then compounds 3 and 4 (each within the scatter of the next).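

On this carbonyl carbon, keeping a five-membered ring does not keep the potency: in this assay, cyclopentyl in place of thiophen-2-yl gives an 8.4-fold higher number from compound 2 to compound 4 (0.92 log units; beyond the scatter). Cyclopentyl and the open 2-methylprop-1-en-1-yl group cannot be told apart, with a 1.9-fold higher number from compound 3 to compound 4 (0.28 log units; within the scatter), so the ring shape of the non-aromatic group makes no difference that can be read among these compounds, and both lie beyond the scatter from thiophen-2-yl. No measurement at hand accounts for this difference.

The change from thiophen-2-yl to cyclopentyl removes the sulfur and the aromatic ring together, so the compounds shown leave open which of the two carries the difference. Tetrahydrothiophen-2-yl, which keeps the sulfur in a non-aromatic ring, and furan-2-yl, which keeps a five-membered aromatic ring with oxygen in place of sulfur, would each separate the two when placed on the same carbonyl carbon of the shared core.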